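The source may hold more compounds than are shown below. What is called first, only, known or untested is meant among the compounds shown, and "the series" means these compounds.

Compound 1, `COc1cccc(Cc2cc(-c3cccs3)nn(CC(=O)Nc3ccc(F)cc3)c2=O)c1`, reaches only the limit > 50000 nM in an assay on HL-60 cells for agonist activity at N-formyl peptide receptor 3 (Homo sapiens), read by calcium flux; a higher number here means that more compound is needed for the effect, a lower number that less compound is needed.
Compound 2, `COc1ccc(-c2cc(Cc3cccc(OC)c3)c(=O)n(CC(=O)Nc3ccc(F)cc3)n2)cc1`, likewise reaches only the limit > 50000 nM in this assay.
Compound 3, `COc1cccc(Cc2cc(-c3ccc(Cl)cc3)nn(CC(=O)Nc3ccc(F)cc3)c2=O)c1`, also reaches only the limit > 50000 nM in this assay.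

Compound 3 thus stands where all three measured compounds stand: the limit of > 50000 nM in this assay, at which 3 of the 3 values shown sit. The steps a step that the two limits leave unreadable from compound 1 to compound 2, a step that the two limits leave unreadable from compound 1 to compound 3 and a step that the two limits leave unreadable from compound 2 to compound 3 have no readable size, both ends of each being limits. Compound 4, `COc1cccc(Cc2cc(-c3ccc(C)cc3)nn(CC(=O)Nc3ccc(F)cc3)c2=O)c1`, differs from compound 3 by methyl in place of chloro on an aromatic carbon. With every measured step unreadable, the expected step of a number no higher from compound 3 to compound 4 (the limit leaves the size open) is none that can be told from the scatter. Compound 4 is therefore expected to sit at the limit as well, estimated at 50000 nM in this assay, with a range from 15000 nM to 50000 nM.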

Compound 4, half-maximal effective concentration: > 50000 nM
Compound 4: only a limit was reported; the forecaster's own chance of this, stated with the estimate: 85%; the middle value lies on the limit itself.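

The steps linking compound 4 to compound 1, compound 2 and compound 3 cannot be read, as both ends of each are limits in this assay. The compounds shown leave open how any of the four compares with another, since all share one position: the limit of > 50000 nM in this assay, at which 4 of the 4 values shown sit.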